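Swapping Chlorine for Bromine: Expected Cytotoxicity on MT4 Cells

This account rests on a few compounds, and the source may have more. Where it says the series, first, only, none or still open, it means among the compounds named here.

Measured compounds:
Compound 1, `Cc1ccc(C(C)C)c(OCc2nnc(SCC(=O)Nc3ccc(Br)cc3)n2Cc2ccccc2)c1`: 66.7 ug/mL
Compound 2, `O=C(CSc1nnc(COc2ccc3ccccc3c2)n1Cc1ccccc1)Nc1ccc(Cl)cc1`: >= 4.93 ug/mL

In a toxicity assay on MT4 cells (Homo sapiens) for cytotoxicity, read by MTT assay, with a stated time of 5 days (on this read-out higher numbers stand for lower toxicity in this test and lower numbers for higher toxicity in this test), compound 1 gives 66.7 ug/mL. For compound 2 only a limit is known: in this assay compound 2 gives >= 4.93 ug/mL, a boundary of the measurement rather than a number, as shown by the limit of >= 4.93 ug/mL in this assay, at which 1 of the 2 values shown sits. Compound 3, `O=C(CSc1nnc(COc2ccc3ccccc3c2)n1Cc1ccccc1)Nc1ccc(Br)cc1`, has not yet been tested. It differs from compound 2 in one place: bromo in place of chloro on an aromatic carbon. Within the data shown here, no step between two measured compounds is available, so nothing here indicates how large such a swap turns out on this shared core. Compound 1 also carries bromo and gives 66.7 ug/mL, which leaves room for compound 3 to sit well inside the measurable range. The step that the limit leaves unreadable from compound 2 to compound 3 is expected to stay within the scatter. Compound 3 is estimated at 30 ug/mL, with a range from 6 ug/mL to 120 ug/mL.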

Compound 3, half-maximal cytotoxic concentration: 58.1 ug/mL
Compound 3: the middle estimate sits 1.9-fold (0.29 log units) below what was measured; low and high end bracket the measured number.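

In this assay, naphthalen-2-yl in place of 2-isopropyl-5-methylphenyl on the oxygen gives a 1.1-fold lower number from compound 1 to compound 3 (0.06 log units; within the scatter), so with bromo held fixed, these two groups cannot be told apart in this test. Among these compounds, this is the first readable step, and compound 3 also provides the first actual number for a compound carrying naphthalen-2-yl. The step from chloro to bromo still cannot be read, because one end of it is only a limit: the limit of >= 4.93 ug/mL in this assay, at which 1 of the 3 values shown sits.

From the compounds shown here alone, whether bromo and chloro differ at this place on the ring therefore remains open. Going by these compounds, it is also open how this assay would respond if an amine, a carboxylic acid or a methoxy group stood there instead of a halogen.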